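From thiophen-2-yl to 3,5-dichlorophenyl on a carbonyl

The source may hold more compounds than are shown below. What is called first, only, known or untested is meant among the compounds shown, and "the series" means these compounds.

In a functional assay on SiHa cells (Homo sapiens) for inhibition (on this read-out higher numbers stand for weaker inhibition and lower numbers for stronger inhibition), compound 1 `COc1cc(/C=C/C(=O)c2cccc(NC(=O)c3c(Cl)cccc3Cl)c2)ccc1O` gives 3.56 ug/mL and compound 2 `COc1cc(/C=C/C(=O)c2cccc(NC(=O)c3cccs3)c2)ccc1O` gives 6.57 ug/mL. Among the compounds with values here, these are the only two numbers so far. Within the data shown here, the one measured step, a 1.8-fold higher number from compound 1 to compound 2 (0.27 log units; within the scatter), lies within the scatter of repeated measurements, so compound 2 cannot be ranked apart from compound 1.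

The next compound, compound 3 `COc1cc(/C=C/C(=O)c2cccc(NC(=O)c3cc(Cl)cc(Cl)c3)c2)ccc1O`, differs from compound 2 in one place: 3,5-dichlorophenyl in place of thiophen-2-yl on a carbonyl carbon. The new group, 3,5-dichlorophenyl, sits on a carbonyl carbon whose other neighbour is an amide-type nitrogen.

The nearest guide is compound 1, which carries 2,6-dichlorophenyl at that place and gives 3.56 ug/mL. Among the measured compounds shown here, no measured compound yet shows how 3,5-dichlorophenyl itself behaves, so this comparison is only a loose one. For the measured compounds named here, since the single step available stayed within the scatter, no clear change is expected in this assay, with at most a slight lean towards a lower number. The expected step is a 1.5-fold lower number from compound 2 to compound 3 (0.16 log units; within the scatter), which would stay within the scatter. For compound 3 the estimated value is 4.5 ug/mL, with an expected range of 2 ug/mL to 10 ug/mL.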

Compound 3, half-maximal inhibitory concentration: 17.7 ug/mL
Compound 3: the middle estimate sits 3.9-fold (0.59 log units) below what was measured; measured number above the stated range.
By their numbers in this assay, from the lowest: compounds 1 and 2 (each within the scatter of the next); then compound 3.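

In this assay, within the data shown here, the group on this carbonyl carbon now shows a real effect: 3,5-dichlorophenyl in place of thiophen-2-yl gives a 2.7-fold higher number from compound 2 to compound 3 (0.43 log units; beyond the scatter) and so weaker inhibition, the first step at this place that lies beyond the scatter. Moving the chlorines matters as well, since 3,5-dichlorophenyl in place of 2,6-dichlorophenyl gives a 5.0-fold higher number from compound 1 to compound 3 (0.70 log units; beyond the scatter) even though both groups are dichlorophenyl rings, so in this small set the pattern of chlorines on the ring counts and not merely their presence. Nothing measured here explains why either change weakens inhibition.

The compounds shown leave open how much of the difference comes from each chlorine, which a ring with a single chlorine, such as 3-chlorophenyl or 2-chlorophenyl, could help to separate. On these data alone, they also carry only aromatic rings on this carbonyl carbon, so it remains unknown how a saturated ring such as cyclohexyl, a short chain such as ethyl, or a phenyl ring bearing an amine or a carboxylic acid would behave at this place.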